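Acyl group swap on the hydroxamate series

This account rests on a few compounds, and the source may have more. Where it says the series, first, only, none or still open, it means among the compounds named here.

Values in a functional assay on A549 cells (Homo sapiens) for antiproliferative activity, read by MTT assay; on this read-out lower numbers stand for stronger inhibition and higher numbers for weaker inhibition:
- compound 1 `COc1cc2c(Oc3ccc(NC(=O)Nc4ccccc4)cc3)ccnc2cc1OCCCCCCC(=O)NO`: 1650 nM
- compound 2 `COc1cc2c(Oc3ccc(NC(=O)N/N=C/c4ccc(F)cc4)cc3)ccnc2cc1OCCCCCCC(=O)NO`: 4920 nM
- compound 3 `COc1cc2c(Oc3ccc(NC(=O)NNC(=O)c4ccccc4F)cc3)ccnc2cc1OCCCCCCC(=O)NO`: 2420 nM

Compound 3 gives 2420 nM in this assay. Its number cannot be separated from that of compound 1, while compound 2 has a higher number than either.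

The next compound is compound 4 `COc1cc2c(Oc3ccc(NC(=O)NNC(=O)c4cccc(C)c4)cc3)ccnc2cc1OCCCCCCC(=O)NO`, which is still unmeasured. The change is 3-methylphenyl in place of 2-fluorophenyl on a carbonyl carbon.

Among the measured compounds shown here, no measured step alters this group alone, so direct evidence is missing. The two steps that lead to compound 3 bear on it only indirectly. Each replaced a larger part of the molecule than this swap does, and both were small: a 1.5-fold higher number from compound 1 to compound 3 (0.17 log units; within the scatter), and a 2.0-fold lower number from compound 2 to compound 3 (0.31 log units; beyond the scatter). The second is only a modest step. Nothing measured points to a direction for the swap, so no shift beyond the scatter is expected in this assay. The expected step is a 1.0-fold higher number from compound 3 to compound 4 (0.01 log units; within the scatter).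

For compound 4 the estimated value is 2500 nM, with an expected range of 1200 nM to 5000 nM.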

Compound 4, half-maximal inhibitory concentration: 8190 nM
The estimate for compound 4 lay 3.3-fold (0.52 log units) below the measured number, and the stated range ends below it.
By their numbers in this assay, from the lowest: compounds 1 and 3 (each within the scatter of the next); then compounds 2 and 4 (each within the scatter of the next).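

In this assay the aryl group on the carbonyl carbon proves not to be a silent position: 3-methylphenyl in place of 2-fluorophenyl gives a 3.4-fold higher number from compound 3 to compound 4 (0.53 log units; beyond the scatter) and this modest step is the only measured one that alters this group alone. The group on the amide-type nitrogen now also reads differently, since ((2-fluorophenyl)carbonyl)amino stayed within the scatter of phenyl, whereas ((3-methylphenyl)carbonyl)amino gives a 5.0-fold higher number from compound 1 to compound 4 (0.70 log units; beyond the scatter) and a 1.7-fold higher number from compound 2 to compound 4 (0.22 log units; within the scatter) places compound 4 within the scatter of the hydrazone-type compound 2, so the two acylated compounds do not behave as one group. No measurement shown here accounts for the step, neither for the loss of the fluorine nor for the gain of the methyl.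

The swap changes both the substituent and its place on the ring, so the two remain unseparated; 2-methylphenyl and 3-fluorophenyl on the same carbonyl carbon would pull them apart. Also open, as far as these compounds go, is whether the trend extends to an unsubstituted phenyl, a pyridyl ring or a methoxy group at this carbonyl, and whether it holds beyond this single cell line.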